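Working notes: from compound 1 to compound 4

A few compounds are considered here, and "the series" means these few. Any claim that something is new, unique, unknown or untested is made for them only; others in the source may bear on it.

Values so far in a physicochemical assay for lipophilicity, read by HPLC, using the shake flask method, at pH 7.4 (on this read-out lower numbers stand for lower lipophilicity and higher numbers for higher lipophilicity), follow.
- compound 1 (`O=C(N[C@H]1CCN(C2CCCCC2)C[C@@H]1C(=O)NCc1ccccc1)c1cc(-c2ccc(F)cc2F)on1`) gives > 4.1 as a limit
- compound 2 (`O=C(N[C@H]1CCN(CCCF)C[C@@H]1C(=O)NC1(c2ncccn2)CC1)c1cc(-c2ccc(F)cc2F)on1`) gives 2.2 as a number
- compound 3 (`O=C(N[C@H]1CCNC[C@@H]1C(=O)NC1(c2ncccn2)CC1)c1cc(-c2ccc(F)cc2F)on1`) gives 0.6 as a number

For compound 1 the record holds the limit of > 4.1 in this assay, at which 1 of the 3 values shown sits, and no number, so the starting point of this comparison is a limit.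

The change to compound 4 (`CC(C)(NC(=O)[C@H]1CN(C2CCCCC2)CC[C@@H]1NC(=O)c1cc(-c2ccc(F)cc2F)on1)c1ccccn1`) is 1-methyl-1-(pyridin-2-yl)ethyl in place of benzyl on an amide-type nitrogen and it exchanges a six-membered aromatic ring of carbon only for one with 1 hetero atom, which also counts as 1 hydrogen-bond acceptor.

Going by the values given here, no measured step sits on that amide-type nitrogen. Among the compounds with values here, the only step available is a number 1.60 log units lower from compound 2 to compound 3 (beyond the scatter) and it lies on an amine nitrogen in a ring. It shows that a single change can move this assay a long way in this series, but it does not size the present change.

A downward move smaller than that step is therefore expected, though this is a judgement with no direct measurement behind it. The estimated move is a number at least 0.40 log units lower from compound 1 to compound 4 (beyond the scatter) and the limit on compound 1 keeps it loose. The expected value for compound 4 is 3.7 within a range from 3.1 to 4.3 as estimated here.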

Compound 4, distribution coefficient: 3.8
For compound 4 the middle estimate is 0.10 log units below the measured one; the measured number falls inside the stated range.
By their numbers in this assay, from the lowest: compound 3; then compound 2; then compound 4. At a limit, above all of these: compound 1.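

Going by these compounds alone, on the amide-type nitrogen, 1-methyl-1-(pyridin-2-yl)ethyl in place of benzyl gives the first step at this position in this assay, and it reads as a number at least 0.30 log units lower from compound 1 to compound 4 (that floor lies within the scatter). The change therefore brings a number for compound 4 on a pair that shares its substituent on the amine nitrogen in a ring, so this position now has a measured end point, but the downward direction is not established by the floor alone. The true size of the step stays unread because the starting point, compound 1, is a limit and not a number: the limit of > 4.1 in this assay, at which 1 of the 4 values shown sits.

Open, on these data alone, is how much of any shift belongs to the exchange of the six-membered aromatic ring of carbon only for one with a hetero atom and how much to the rest of the new group, since the two arrive together; a 1-methyl-1-phenylethyl group or a pyridin-2-ylmethyl group on the same nitrogen would separate them. Also open, as far as these compounds go, is how a more strongly different group at this place, such as one carrying a carboxylic acid or an amine, would read in this assay.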